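The compounds below may be only part of what the source reports. "The series", "measured", "known", "first", "only" and "open" are said of these compounds alone.

Compound 1 `O=[N+]([O-])c1ccccc1CNc1cccc2[nH]ncc12` is the stronger of the two compounds measured in an assay for inhibition of Tryptophan 2,3-dioxygenase (Homo sapiens), with stated times of 10 min and 60 min, tested at 100 uM; on this read-out higher numbers stand for a stronger effect at the one concentration tested and lower numbers for a weaker effect: compound 1 gives 87%, the highest of the two numbers. Compound 2 `FC(F)(F)c1cccc(CNc2cc(C(F)(F)F)cc3[nH]ncc23)c1` gives 74% in this assay, a gap beyond the usual scatter. Compound 3 `O=[N+]([O-])c1ccccc1CNc1cc(Br)cc2[nH]ncc12` has not been measured; it differs from compound 1 by bromo in place of hydrogen on an aromatic carbon. Among the compounds with values here, no measured pair isolates this change, so the expectation rests only on the level of compound 1. The step is expected to be small, a number 6 percentage points lower from compound 1 to compound 3 (within the scatter), in either direction or none beyond the scatter. Compound 3 is estimated at 81%, in the range 62% to 93%.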

Compound 3, a percentage reported as inhibition, at one concentration (the size of the read-out at that concentration, not a potency): 64%
Compound 3: the middle estimate sits 17 percentage points above what was measured; measured number inside the range.
By their numbers in this assay, from the lowest: compounds 3 and 2 (each within the scatter of the next); then compound 1.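

Bromo in place of hydrogen on this aromatic carbon, meta to a large group, gives a number 23 percentage points lower from compound 1 to compound 3 (beyond the scatter) in this assay. Within the data shown here, this is the first change in one place, and it shows that a single bromine atom on this carbon of the core of compound 1 is enough to move the read-out beyond the scatter. Nothing at hand gives a reason for this step.

Going by these compounds, whether the step belongs to bromo alone or to any group on this carbon stays open. Fluoro, methyl or an amine in the same place would separate the two readings.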